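The source may report more compounds than this note shows. Statements on the series, on what has been measured and on what is new or still open speak of the compounds shown alone.

Three compounds have been measured:

Compound 1 `NC1=NC2(CCOCC2)N(OCCCOc2cccc(Cl)c2)C(N)=N1`: 520 nM
Compound 2 `Cc1ccc(OCCCON2C(N)=NC(N)=NC23CCOCC3)cc1`: 2580 nM
Compound 3 `NC1=NC2(CCOCC2)N(OCCCOc2ccccc2Cl)C(N)=N1`: 660 nM

These numbers come from a functional assay on HL-60 cells (Homo sapiens) for antiproliferative activity, read by MTT assay, with a stated time of 72 h; on this read-out higher numbers stand for weaker inhibition and lower numbers for stronger inhibition. Compound 1 gives the lowest of the three numbers, but its separation from compound 3 is within the scatter, so the two cannot be ranked against each other; compound 2 sits clearly apart, giving a 5.0-fold higher number from compound 1 to compound 2 (0.70 log units; beyond the scatter). The step of a 1.3-fold higher number from compound 1 to compound 3 (0.10 log units; within the scatter) shows that moving the chlorine around the aromatic ring costs nothing that can be resolved here.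

The unmeasured compound 4 `COc1ccc(OCCCON2C(N)=NC(N)=NC23CCOCC3)cc1` is related to compound 1 by a single change: 4-methoxyphenyl in place of 3-chlorophenyl on an oxygen on a saturated carbon. Among the measured compounds shown here, two measured steps bear on this. The step from compound 1 to compound 3 keeps a halogen on the ring and stays within the scatter, whereas the step from compound 1 to compound 2, which puts a 4-methylphenyl in the same place, is a modest rise beyond the scatter. Compound 4 carries a 4-methoxyphenyl, and compound 2 is the closer precedent, so a rise in the number in this assay is expected, probably smaller than or similar to that seen with compound 2. For compound 4 the expected step is a 3.5-fold higher number from compound 1 to compound 4 (0.54 log units; beyond the scatter). Compound 4 is therefore estimated at 1800 nM, with a likely range from 800 nM to 4500 nM.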

Compound 4, half-maximal inhibitory concentration: 1670 nM
Compound 4: the middle estimate sits 1.1-fold (0.03 log units) above what was measured; measured number inside the range.
By their numbers in this assay, from the lowest: compounds 1 and 3 (each within the scatter of the next); then compounds 4 and 2 (each within the scatter of the next).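

In this assay the 4-methoxyphenyl group on an oxygen on a saturated carbon separates clearly from the 3-chlorophenyl group, with a 3.2-fold higher number from compound 1 to compound 4 (0.51 log units; beyond the scatter) as the step, and also from the 2-chlorophenyl group, with a 2.5-fold higher number from compound 3 to compound 4 (0.40 log units; beyond the scatter) as the step. Methoxy in place of methyl on an aromatic carbon, by contrast, gives a 1.5-fold lower number from compound 2 to compound 4 (0.19 log units; within the scatter) and so cannot be told apart from the 4-methylphenyl group, which means the four compounds now fall into two groups: the two chlorophenyl compounds, 1 and 3, at the low end, and the two compounds without chlorine, 2 and 4, at the higher end, with none going against this split. No evidence is at hand that accounts for this split.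

What stays open is whether the split follows the chlorine itself or the place of the substituent on the ring, since 4-chlorophenyl is not among these compounds and it would separate the two readings. Also open, from the compounds shown here alone, is how an unsubstituted phenyl, a ring carrying an amine or a carboxylic acid, or a longer chain in place of the present one would fall relative to these two groups.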